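Swapping a bromobenzyl for a long chain on the triazole

A few compounds are considered here, and "the series" means these few. Any claim that something is new, unique, unknown or untested is made for them only; others in the source may bear on it.

The compounds measured so far:
- compound 1, `O=C(CN1CCC(Cc2ccccc2)CC1)Nc1ccc(C(=O)/C=C/c2cn(Cc3ccc(Br)cc3)nn2)cc1`: 54500 nM
- compound 2, `O=C(CBr)Nc1ccc(C(=O)/C=C/c2cn(Cc3ccc(Br)cc3)nn2)cc1`: 10100 nM
- compound 3, `CCCCCCCCn1cc(/C=C/C(=O)c2ccc(NC(=O)CN3CCC(Cc4ccccc4)CC3)cc2)nn1`: 52600 nM

All three were tested in a functional assay on MCF7 cells (Homo sapiens) for inhibition, read by MTT assay; a higher number here means a weaker inhibitor, a lower number a stronger inhibitor. Among them compound 2 gives the lowest number, with both compound 1 and compound 3 standing beyond the scatter above it.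

Compound 4, `CCCCCCCCCCn1cc(/C=C/C(=O)c2ccc(NC(=O)CBr)cc2)nn1`, has not yet been measured. It differs from compound 2 in one place: nonyl in place of 4-bromophenyl on a saturated chain carbon bound to an aromatic nitrogen. Compound 2 and compound 4 thus share a core, and only the group on the saturated chain carbon bound to the aromatic nitrogen changes.

Within the data shown here, one measured step bears on this change. The same kind of swap, heptyl in place of 4-bromophenyl at that position, gave a 1.0-fold lower number from compound 1 to compound 3 (0.02 log units; within the scatter). That step lay within the scatter, so the chain length on the aromatic nitrogen appears to matter little in this assay for that pair.

On this basis the step of a 1.0-fold higher number from compound 2 to compound 4 (0.02 log units; within the scatter) is expected to stay within the scatter. Compound 4 is therefore estimated at 10500 nM, with a range from 4000 nM to 28000 nM.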

Compound 4, half-maximal inhibitory concentration: 9760 nM
Compound 4: the middle estimate sits 1.1-fold (0.03 log units) above what was measured; the range from low to high includes it.
By their numbers in this assay, from the lowest: compounds 4 and 2 (each within the scatter of the next); then compounds 3 and 1 (each within the scatter of the next).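

In this assay, replacing the 4-bromophenyl with nonyl gives a 1.0-fold lower number from compound 2 to compound 4 (0.01 log units; within the scatter) and so leaves the reading effectively where it was. The earlier swap to heptyl, which gave a 1.0-fold lower number from compound 1 to compound 3 (0.02 log units; within the scatter), showed this only for compounds carrying the larger side chain of compound 1; the same insensitivity now also appears with the small bromine-bearing side chain of compound 2, and a ring-free chain again stands in for an aromatic ring at this position. No measurement at hand explains why this group can be exchanged so freely.

On these data alone, both swaps put in plain carbon chains, so it remains open whether a chain ending in an amine or a carboxylic acid would behave alike. As far as these compounds go, a much shorter chain, such as ethyl, is an equally open case.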